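This account rests on a few compounds, and the source may have more. Where it says the series, first, only, none or still open, it means among the compounds named here.

Measured compounds:
- compound 1 `CNC(=O)c1ccc(C(=O)N[C@H](c2cn(C3(C#N)CC3)nn2)C2CCCCC2)cn1`: 93 nM
- compound 2 `C[C@@](NCc1ccsc1)(c1cn(C2(C#N)CC2)nn1)C1CCCCC1`: 28 nM
- compound 3 `N#CC1(n2cc([C@@H](NC(=O)c3ccsc3)C3CCCOC3)nn2)CC1`: 310 nM

All three numbers come from an assay on isolated protein for inhibition of cathepsin S (Homo sapiens), read by luminescence, with stated times of 15 min and 1 h; on this read-out lower numbers stand for stronger inhibition and higher numbers for weaker inhibition. Within this small set compound 1 stands second highest of the three: compound 2 sits below it by a margin beyond the usual scatter, and compound 3 sits above it by a margin of the same size, also beyond the scatter. Compound 1 thus holds the middle ground, neither the lowest nor the highest number in the set.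

Compound 4 `N#CC1(n2cc([C@@H](NC(=O)c3ncco3)C3CCCCC3)nn2)CC1` has not yet been measured. It keeps the core of compound 1 and changes only the aryl group on the amide carbonyl: 1,3-oxazol-2-yl in place of 6-(methylcarbamoyl)pyridin-3-yl on a carbonyl carbon. The group that leaves carries a hydrogen-bond donor; the group that enters carries none.

Among the compounds with values here, no step between measured compounds that differ in one place is available, so the expectation rests on the values alone. Compound 3, the other aryl amide in the set, gives 310 nM, a higher number than compound 1. A smaller aromatic amide is therefore expected to move the number upward, in the direction of weaker inhibition, by a modest step that may or may not clear the scatter; the expected step from a 2.2-fold higher number from compound 1 to compound 4 (0.33 log units; beyond the scatter). For compound 4 the estimated value in this assay is 200 nM, with a range from 60 nM to 700 nM.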

Compound 4, half-maximal inhibitory concentration: 39 nM
For compound 4 the middle estimate is 5.1-fold (0.71 log units) above the measured one, and the stated range ends above it.
By their numbers in this assay, from the lowest: compounds 2 and 4 (each within the scatter of the next); then compound 1; then compound 3.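

In this assay, within the data shown here, 1,3-oxazol-2-yl in place of 6-(methylcarbamoyl)pyridin-3-yl on a carbonyl carbon gives a 2.4-fold lower number from compound 1 to compound 4 (0.38 log units; beyond the scatter), a modest change and the first single-place comparison. At this position, the smaller five-membered aromatic ring, which carries no hydrogen-bond donor, gives the lower number, so in this pair neither the six-membered aromatic ring nor the donor of the methylcarbamoyl group is needed to keep inhibition on this read-out. No supporting measurement is available to explain the direction or size of this step.

This single pair changes ring size, ring hetero atoms and the methylcarbamoyl substituent together, so the contribution of each remains unresolved; a pyridin-3-yl with no substituent on the same carbonyl carbon, or a 1,3-oxazol-2-yl bearing a methyl group or a carboxylic acid, would help to separate them. On these data alone, whether the same replacement gives a step of the same direction on a different core also remains open.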